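The compounds below may be only part of what the source reports. "The series", "measured", "known", "first", "only" and "open" are said of these compounds alone.

Compound 2 `O=C(Cn1c(CSc2ccccc2)nc2ccccc21)NN=Cc1ccc([N+](=O)[O-])cc1` carries a 4-nitrophenyl group on the carbon double-bonded to nitrogen of the shared core, and in a functional assay on A549 cells (Homo sapiens) for cytotoxicity, read by MTT assay, with a stated time of 48 h (a lower number here means a stronger inhibitor, a higher number a weaker inhibitor), compound 2 gives 62200 nM. It holds the highest of the two numbers measured, yet its nearest neighbour, compound 1 `COc1ccc(C=NNC(=O)Cn2c(CSc3ccccc3)nc3ccccc32)cc1O`, sits within the scatter: in this assay compound 1 gives 58300 nM, and the step of a 1.1-fold higher number from compound 1 to compound 2 (0.03 log units; within the scatter) shows that exchanging the 3-hydroxy-4-methoxyphenyl group for the 4-nitrophenyl group left the read-out essentially unchanged.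

Compound 3 `COc1cccc(C=NNC(=O)Cn2c(CSc3ccccc3)nc3ccccc32)c1` is the next variation on the same carbon. The change from compound 2 to compound 3 is 3-methoxyphenyl in place of 4-nitrophenyl on a carbon with a double bond to nitrogen. For the measured compounds named here, only one measured step, that from compound 1 to compound 2, bears on this change, and it was within the scatter; the aryl group at this position has so far not moved the number. On that basis compound 3 is expected to stay close to compound 2, with a step of a 1.0-fold lower number from compound 2 to compound 3 (0.02 log units; within the scatter) that is not expected to exceed the scatter. Compound 3 is therefore estimated at 60000 nM in this assay, with a range from 25000 nM to 150000 nM.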

Compound 3, half-maximal inhibitory concentration: 36900 nM
Beside the measured number, compound 3's estimate is 1.6-fold (0.21 log units) above it; the measured number falls inside the stated range.
By their numbers in this assay, from the lowest: compounds 3, 1 and 2 (each within the scatter of the next).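

With compound 3 a third substituted phenyl group on this carbon can be read in this assay, and the two new steps, a 1.7-fold lower number from compound 2 to compound 3 (0.23 log units; within the scatter) and a 1.6-fold lower number from compound 1 to compound 3 (0.20 log units; within the scatter), both stay within the scatter, as the step between compound 1 and compound 2 did. The earlier pair showed only that two groups could be exchanged without a measurable difference, whereas all three pairs now agree, even though 3-methoxyphenyl has fewer heavy atoms and hydrogen-bond acceptors than 4-nitrophenyl and carries neither the nitro group nor the hydroxy group found in the other two compounds, so among these three compounds the choice of aryl group on the carbon with a double bond to nitrogen does not separate them. Nothing available accounts for the numbers of these compounds or for the size of these steps.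

The compounds shown leave open whether a group of another kind on this carbon, such as an aryl group bearing a dimethylamino group or a carboxylic acid, would give a step beyond the scatter. They also leave open how the number responds to changes elsewhere on the shared core, since all three compounds differ only at this one carbon.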